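Swapping the ring on the triple-bonded carbon

A few compounds are considered here, and "the series" means these few. Any claim that something is new, unique, unknown or untested is made for them only; others in the source may bear on it.

Compound 1 `CNC(=O)[C@@]12C[C@@H]1[C@@H](n1cnc3c(NC)nc(C#Cc4ccccc4OC)nc31)[C@H](O)[C@@H]2O` gives 0.77 nM in an assay on CHO cells for displacement of a labelled ligand from adenosine receptor A3 (Homo sapiens), read by scintillation counting, with a stated time of 60 min; a higher number here means a weaker inhibitor, a lower number a stronger inhibitor.
Compound 2 `CNC(=O)[C@@]12C[C@@H]1[C@@H](n1cnc3c(NC)nc(C#Cc4ccc(OC)cc4)nc31)[C@H](O)[C@@H]2O` gives 0.63 nM in this assay.
Compound 3 `CNC(=O)[C@@]12C[C@@H]1[C@@H](n1cnc3c(NC)nc(C#Cc4cccc(C(F)(F)F)c4)nc31)[C@H](O)[C@@H]2O` gives 3.39 nM in this assay.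

Compound 3 stands at the highest of the three numbers: a 4.4-fold higher number from compound 1 to compound 3 (0.64 log units; beyond the scatter) and a 5.4-fold higher number from compound 2 to compound 3 (0.73 log units; beyond the scatter), so compound 3 is the weakest inhibitor of the three measured here. Compound 4 `CNC(=O)[C@@]12C[C@@H]1[C@@H](n1cnc3c(NC)nc(C#Cc4cc(C)c(C)o4)nc31)[C@H](O)[C@@H]2O` differs from compound 3 in one place: 4,5-dimethylfuran-2-yl in place of 3-(trifluoromethyl)phenyl on a triple-bonded carbon.

All three measured steps alter the ring on the triple-bonded carbon, so all of them bear on this change. a 1.2-fold lower number from compound 1 to compound 2 (0.09 log units; within the scatter), whereas a 4.4-fold higher number from compound 1 to compound 3 (0.64 log units; beyond the scatter) and a 5.4-fold higher number from compound 2 to compound 3 (0.73 log units; beyond the scatter) show that exchanging the ring at this position can move the number by a modest amount. Among the measured compounds shown here, no measured compound carries a five-membered ring there, so the direction for compound 4 cannot be read off directly. Since compound 3 already sits at the high end, a return toward the numbers of compound 1 and compound 2 seems somewhat more likely than a further rise, but a number close to compound 3 is also possible.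

Compound 4 is therefore expected to give 1.5 nM, with a range of 0.4 nM to 6 nM. This means an expected 2.3-fold lower number from compound 3 to compound 4 (0.35 log units; beyond the scatter).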

Compound 4, inhibition constant: 1.45 nM
The estimate for compound 4 lay 1.0-fold (0.01 log units) above the measured number; the range from low to high includes it.
By their numbers in this assay, from the lowest: compounds 2, 1 and 4 (each within the scatter of the next, the first and the last beyond it); then compound 3.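

The ring on the triple-bonded carbon need not be a six-membered ring of carbon only for the number in this assay to stay low: 4,5-dimethylfuran-2-yl, with fewer heavy atoms than 3-(trifluoromethyl)phenyl, gives a 2.3-fold lower number from compound 3 to compound 4 (0.37 log units; beyond the scatter). Against 2-methoxyphenyl the same group gives a 1.9-fold higher number from compound 1 to compound 4 (0.27 log units; within the scatter), so these two rings cannot be told apart, whereas against 4-methoxyphenyl it gives a 2.3-fold higher number from compound 2 to compound 4 (0.36 log units; beyond the scatter), which leaves the furan ring modestly behind that group. Across the four compounds, this position therefore accepts a five-membered aromatic ring with one hetero atom as well as the three substituted phenyl rings, and the numbers differ by no more than modest steps.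

No measurement of any property of these groups is available to explain their order in this assay.
On these data alone, a furan-2-yl ring without its two methyl groups, a ring carrying an amine or a carboxylic acid, and a plain alkyl chain in place of any ring all remain open at this position.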